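Three Esters of One Core: What Compound 4 May Show

The compounds below may be only part of what the source reports. "The series", "measured", "known", "first", "only" and "open" are said of these compounds alone.

Three esters sharing one core were tested in an ADME assay on HepG2 2.2.15 cells (Homo sapiens) for cytotoxicity; on this read-out higher numbers stand for lower toxicity in this test and lower numbers for higher toxicity in this test:
compound 1, `N#CCC(=O)OCCc1c(-c2ccccc2Cl)c2cc(Cl)ccc2[nH]c1=O`: 100000 nM
compound 2, `O=C(OCCc1c(-c2ccccc2Cl)c2cc(Cl)ccc2[nH]c1=O)c1ccco1`: 98000 nM
compound 3, `O=C(COc1ccccc1)OCCc1c(-c2ccccc2Cl)c2cc(Cl)ccc2[nH]c1=O`: 81000 nM

Compound 3 gives the lowest of these three numbers, but its distance to compound 2 and to compound 1 lies within the scatter, so the three cannot be ordered. Compound 4, `COc1ccc(/C=C/C(=O)OCCc2c(-c3ccccc3Cl)c3cc(Cl)ccc3[nH]c2=O)cc1OC`, differs from compound 3 in one place: 2-(3,4-dimethoxyphenyl)ethenyl in place of phenoxymethyl on a carbonyl carbon. Going by the values given here, the steps that bear on this change are the two that also exchanged the group on the carbonyl carbon, a 1.0-fold lower number from compound 1 to compound 2 (0.01 log units; within the scatter) and a 1.2-fold lower number from compound 2 to compound 3 (0.08 log units; within the scatter), neither of them beyond the scatter. The writer therefore expects no step beyond the scatter in this assay, a 1.0-fold higher number from compound 3 to compound 4 (0.02 log units; within the scatter). The estimate for compound 4 is 85000 nM, within a range from 40000 nM to 180000 nM.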

Compound 4, half-maximal cytotoxic concentration: > 1200000 nM
Compound 4 was reported as a limit; the forecaster's own chance of this, stated with the estimate: 25%; middle value at least 14-fold (1.14 log units) away from the limit.
By their numbers in this assay, from the lowest: compounds 3, 2 and 1 (each within the scatter of the next). At a limit, above all of these: compound 4.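

In this assay compound 4 is reported only as a limit, not as a number: the limit of > 1200000 nM in this assay, at which 1 of the 4 values shown sits. Even so, the group on the carbonyl carbon, whose exchanges among compound 1, compound 2 and compound 3 stayed within the scatter, proves able to shift this read-out: there is an at least 14-fold higher number from compound 3 to compound 4 (1.17 log units; beyond the scatter), an at least 12-fold higher number from compound 2 to compound 4 (1.08 log units; beyond the scatter), and an at least 12-fold higher number from compound 1 to compound 4 (1.07 log units; beyond the scatter).

The compounds shown leave open whether the ethenyl link or the 3,4-dimethoxyphenyl ring carries this step, as the two enter together. As far as these compounds go, how a plain 2-phenylethenyl group, or an amine or carboxylic acid on that ring, would read here also stays open.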